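A few compounds are considered here, and "the series" means these few. Any claim that something is new, unique, unknown or untested is made for them only; others in the source may bear on it.

Two compounds of this series have numbers in an assay on cells for displacement of a labelled ligand from adenosine receptor A1 (Homo sapiens), with a stated time of 60 min, tested at 1 uM; on this read-out higher numbers stand for more inhibition at the one concentration tested (going by the name of the read-out) and lower numbers for less inhibition. Compound 2 `CC1=C(C(=O)OC(C)C)C(c2ccccc2)N/C(=N/C#N)N1` gives 20%, and compound 1 `CC1=C(C(=O)OC(C)C)[C@H](c2ccco2)N/C(=N/C#N)N1` gives 18%; the two numbers lie within the scatter of each other, so neither stands apart. Compound 3 `CC1=C(C(=O)OC(C)C)C(c2ccoc2)N/C(=N/C#N)N1` has not been measured. It differs from compound 2 by furan-3-yl in place of phenyl on a saturated ring carbon. Going by the values given here, no step between measured compounds is available for this kind of change, so the expectation rests on the two values alone, which point to no step beyond the scatter. Compound 3 is expected to give 19%, within a range from 8% to 32%, a step of a number 1 percentage points lower from compound 2 to compound 3 (within the scatter) estimated to stay inside the scatter.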

Compound 3, a percentage reported as inhibition, at one concentration (the size of the read-out at that concentration, not a potency): 34%
Compound 3: middle estimate off by 15 percentage points, on the low side; measured number above the stated range.
By their numbers in this assay, from the lowest: compounds 1 and 2 (each within the scatter of the next); then compound 3.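

In this assay, the saturated ring carbon proves sensitive to the aromatic ring it carries: furan-3-yl in place of phenyl gives a number 14 percentage points higher from compound 2 to compound 3 (beyond the scatter). This is a modest step, but the two earlier values gave no sign that a change here could move the read-out beyond the scatter. Nothing available accounts for the step.

A single pair cannot separate the effect of the ring oxygen from that of the five-membered ring. From the compounds shown here alone, how a thiophene or pyridine ring at this carbon would read remains open.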